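A few compounds are considered here, and "the series" means these few. Any claim that something is new, unique, unknown or untested is made for them only; others in the source may bear on it.

Going by the values given here, in an ADME assay on cells (Homo sapiens) for cytotoxicity, read by resazurin assay, with a stated time of 5 days (on this read-out higher numbers stand for lower toxicity in this test and lower numbers for higher toxicity in this test), compound 1 `O=S(=O)(Cc1nc(-c2ccc(Cl)nc2)c2sccc2n1)c1cccc(Cl)c1` gives 70000 nM, the higher of the two numbers measured so far. Among the compounds with values here, the only other measured compound, compound 2 `COc1ccc(-c2nc(CC(O)c3cccc(Cl)c3)nc3ccsc23)cn1`, gives 31000 nM, a lower number by more than the usual scatter of repeat measurements. Compound 1 and compound 2 differ in more than one place, so their gap cannot be tied to any single change. Compound 3 `O=c1ccc(-c2nc(CS(=O)(=O)c3cccc(Cl)c3)nc3ccsc23)c[nH]1` differs from compound 1 in one place only: a group of 7 heavy atoms (5 carbon, 1 nitrogen, 1 oxygen; one six-membered aromatic ring with 1 hetero atom) in place of a group of 7 heavy atoms (5 carbon, 1 nitrogen, 1 chlorine; one six-membered aromatic ring with 1 hetero atom), on an aromatic carbon. Within the data shown here, the 6-chloropyridin-3-yl group is replaced by a ring of the same size, and no measured pair shows this swap, so any expectation here is rough. The expected change is a 1.1-fold lower number from compound 1 to compound 3 (0.03 log units; within the scatter), which would be no step beyond the scatter. For compound 3 the estimated value is 65000 nM, with an expected range of 25000 nM to 120000 nM.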

Compound 3, half-maximal cytotoxic concentration: > 50000 nM
Compound 3: only a limit was reported; the forecaster's own chance of this, stated with the estimate: 30%; the middle value lies beyond the limit too.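

In this assay compound 3 gives > 50000 nM, which is a limit and not a number. Going by these compounds alone, no step from compound 1 to compound 3 can therefore be read. The compounds shown leave open whether replacing the 6-chloropyridin-3-yl group changes this read-out at all, and in which direction.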